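Swapping a carbamate for a sulfur analogue on the sugar arm

This account rests on a few compounds, and the source may have more. Where it says the series, first, only, none or still open, it means among the compounds named here.

Compound 1, `CNC(=O)OC[C@H]1OC(n2cnc3c(NC4CCOC4)nc(Cl)nc32)[C@H](O)[C@@H]1O`, gives 96 nM in an assay on DDT1 cells (Cricetulus griseus) for binding affinity to adenosine receptor A1 (Homo sapiens), read by radioligand binding; on this read-out higher numbers stand for weaker inhibition and lower numbers for stronger inhibition.
Compound 2, `C/N=C(\S)OC[C@H]1OC(n2cnc3c(NC4CCOC4)nc(Cl)nc32)[C@H](O)[C@@H]1O`, gives 71 nM in this assay.
Compound 3, `CC(C)NC(=O)OC[C@H]1OC(n2cnc3c(NC4CCOC4)ncnc32)[C@H](O)[C@@H]1O`, gives 78 nM in this assay.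

Compound 3 sits in the middle of these three numbers, and both of its neighbours lie within the usual scatter of it: compound 2 is nearest and compound 1 furthest. The unmeasured compound 4, `C=CC/N=C(\S)OC[C@H]1OC(n2cnc3c(NC4CCOC4)ncnc32)[C@H](O)[C@@H]1O`, differs from compound 3 at one spot: a group of 6 heavy atoms (4 carbon, 1 nitrogen, 1 sulfur; no ring) in place of a group of 6 heavy atoms (4 carbon, 1 nitrogen, 1 oxygen; no ring), on an oxygen on a saturated carbon. The isopropylcarbamoyl group leaves, and a group with sulfur instead of oxygen and two double bonds outside aromatic rings enters, on an oxygen on a saturated carbon. Among the compounds with values here, one measured step bears on this: a 1.4-fold lower number from compound 1 to compound 2 (0.13 log units; within the scatter), where the same kind of oxygen-for-sulfur exchange on that oxygen left the number within the scatter. Within the data shown here, no measured step covers the change in the carbon chain of the group. For compound 4 no step beyond the scatter is therefore expected in this assay, and the estimate is a 1.3-fold lower number from compound 3 to compound 4 (0.11 log units; within the scatter). Compound 4 is estimated at 60 nM, with a range from 25 nM to 150 nM.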

Compound 4, inhibition constant: 35 nM
Compound 4: the middle estimate sits 1.7-fold (0.23 log units) above what was measured; the range from low to high includes it.
By their numbers in this assay, from the lowest: compound 4; then compounds 2, 3 and 1 (each within the scatter of the next).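

In this assay, within the data shown here, a 2.2-fold lower number from compound 3 to compound 4 (0.35 log units; beyond the scatter) is the only step on this oxygen on a saturated carbon to pass beyond the scatter, though it is modest, so a change here can move the number. The other step, a 1.4-fold lower number from compound 1 to compound 2 (0.13 log units; within the scatter), stayed within the scatter and left the carbon part of the group alone, whereas here the isopropylcarbamoyl group leaves and the entering group differs in both its sulfur and its carbon chain, with 2 double bonds outside aromatic rings. Nothing on hand explains why the number moved.

Whether the sulfur or the carbon chain accounts for the step stays open; the same sulfur group carrying an isopropyl chain would separate the two. Also open, going by these compounds, is how a longer chain, such as butyl, or an amine at the end of the chain would fare on this oxygen.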